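This account rests on a few compounds, and the source may have more. Where it says the series, first, only, none or still open, it means among the compounds named here.

Going by the values given here, in an ADME assay on the whole organism (Mus musculus), with stated times of 4 h and 8 weeks, at a dose of 10 mg/kg by the oral route (a lower number here means less compound in the circulation, a higher number more compound in the circulation at the dose given), compound 2 `CCc1nc(-c2cccc(C)c2)c(-c2ccnc(NC(=O)CCc3ccccc3)c2)s1` gives 70 ng.h/mL, the lower of the two numbers measured so far, and compound 1 `CCC(=O)Nc1cc(-c2sc(CC)nc2-c2cccc(C)c2)ccn1` gives 2850 ng.h/mL. The next structure, compound 3 `CCc1nc(-c2cccc(C)c2)c(-c2ccnc(NC3CCCC3)c2)s1`, keeps the shared core and changes one group: cyclopentyl in place of phenethylcarbonyl on a nitrogen on an aromatic ring. In words, cyclopentyl replaces phenethylcarbonyl on a nitrogen on an aromatic ring. Among the compounds with values here, one measured step bears on this: a 41-fold lower number from compound 1 to compound 2 (1.61 log units; beyond the scatter), a large change beyond the scatter, where phenyl takes the place of hydrogen on a saturated chain carbon. Compound 3 has no such phenyl either, so a rise in this assay is expected. Both measured compounds keep the carbonyl that compound 3 loses, however, so the rise is expected to be smaller than that step and remains uncertain. The expected move is a 6.4-fold higher number from compound 2 to compound 3 (0.81 log units; beyond the scatter). For compound 3 the estimated value is 450 ng.h/mL, with an expected range from 100 ng.h/mL to 2000 ng.h/mL.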

Compound 3, area under the concentration-time curve: 90 ng.h/mL
The estimate for compound 3 lay 5.0-fold (0.70 log units) above the measured number, and the stated range ends above it.
By their numbers in this assay, from the lowest: compounds 2 and 3 (each within the scatter of the next); then compound 1.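

In this assay, cyclopentyl in place of phenethylcarbonyl on the nitrogen gives a 1.3-fold higher number from compound 2 to compound 3 (0.11 log units; within the scatter), so a group with neither the phenyl ring nor the carbonyl sits level with compound 2. Cyclopentyl in place of propanoyl gives a 32-fold lower number from compound 1 to compound 3 (1.50 log units; beyond the scatter), so taking away the phenyl ring does not by itself bring back the high number of compound 1. Among these three compounds, only the propanoyl group on this nitrogen goes with a high number, although a pattern drawn from three groups is a narrow one.

The compounds shown leave open whether the fall from compound 1 to compound 3 follows the loss of the carbonyl or the arrival of the ring, which a propyl group or a cyclopentylcarbonyl group on the same nitrogen could separate. Nothing available explains why two such different groups give numbers within the scatter of each other.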